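Swapping One Halogen at the Far End of Compound 1

The compounds below may be only part of what the source reports. "The series", "measured", "known", "first", "only" and "open" are said of these compounds alone.

Of the compounds shown here, three have so far been measured in a functional assay on ACHN cells (Homo sapiens) for inhibition, read by sulforhodamine B assay, with a stated time of 48 h; a lower number here means a stronger inhibitor of growth, a higher number a weaker inhibitor of growth. Compound 1 `N=C(N)c1ccc(-c2ccc(-c3ccc(Cl)cc3)o2)o1` gives 1890 nM, compound 2 `COc1cc(OC)cc(-c2ccc(-c3ccc(C(=N)N)o3)o2)c1` gives 2050 nM, and compound 3 `N=C(N)c1ccc(-c2ccc(-c3ccc4ccccc4c3)s2)s1` gives 2530 nM. Compound 1 has the lowest of the three numbers, but both others lie within the usual scatter of it, so no order among the three can be claimed. Compound 4 `N=C(N)c1ccc(-c2ccc(-c3ccc(F)cc3)o2)o1` differs from compound 1 in a single place: fluoro in place of chloro on an aromatic carbon. Among the measured compounds shown here, no measured pair shows this exact change, so its size is unknown. A small step toward a higher number is expected, if any at all, and possibly none beyond the scatter; the estimated step is a 1.3-fold higher number from compound 1 to compound 4 (0.12 log units; within the scatter). In this assay compound 4 is expected to give about 2500 nM, within a range from 1200 nM to 5500 nM.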

Compound 4, concentration for 50% growth inhibition: 1600 nM
Compound 4: middle estimate off by 1.6-fold (0.19 log units), on the high side, within the range that was stated.
By their numbers in this assay, from the lowest: compounds 4, 1, 2 and 3 (each within the scatter of the next).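

In this assay, fluoro in place of chloro on an aromatic carbon, para to a large group, gives a 1.2-fold lower number from compound 1 to compound 4 (0.07 log units; within the scatter) and so leaves the two compounds indistinguishable. This is the first pair shown that differs in one place, and it shows that this exchange of one halogen for another does not move the number beyond the scatter. Nothing available explains the result.

Going by these compounds, it remains open whether bromo, an amine, a carboxylic acid or a longer chain at this position would give a number beyond the scatter of compound 1.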